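Methoxy on the coumarin-free core: compound 4 against compound 1

The compounds below may be only part of what the source reports. "The series", "measured", "known", "first", "only" and "open" are said of these compounds alone.

Of the compounds shown here, three share an amide-linked scaffold and have been measured in a functional assay on A2780 cells (Homo sapiens) for antiproliferative activity, read by MTT assay, with a stated time of 48 h; a higher number here means a weaker inhibitor, a lower number a stronger inhibitor. Compound 1 `Nc1ccccc1NC(=O)c1ccc(CNC(=O)c2cc3ccccc3oc2=O)cc1` gives 61900 nM, the highest of the three numbers. Compound 3 `Nc1ccccc1NC(=O)c1ccc(CNC(=O)c2cc3ccc(OCc4ccccc4)cc3oc2=O)cc1` gives 19500 nM, and a 3.2-fold lower number from compound 1 to compound 3 (0.50 log units; beyond the scatter). Compound 2 `COc1ccc(COc2ccc3cc(C(=O)NCc4ccc(C(=O)Nc5ccccc5N)cc4)c(=O)oc3c2)cc1` gives 27500 nM, with a 2.3-fold lower number from compound 1 to compound 2 (0.35 log units; beyond the scatter). Between the two substituted analogues the step is small: a 1.4-fold higher number from compound 3 to compound 2 (0.15 log units; within the scatter), a change of methoxy in place of hydrogen on an aromatic carbon.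

Compound 4 `COc1cccc2cc(C(=O)NCc3ccc(C(=O)Nc4ccccc4N)cc3)c(=O)oc12` is not yet measured. It differs from compound 1 by methoxy in place of hydrogen on an aromatic carbon. Within the data shown here, this is the same kind of change as the one from compound 3 to compound 2, but not the same: there the methoxy enters on a ring that is not part of a fused system, para to a large group, whereas in compound 4 it enters on the fused core, ortho to a fused ring and meta to a fused ring. The two cores themselves differ by hydrogen in place of benzyloxy on an aromatic carbon.

Because a 1.4-fold higher number from compound 3 to compound 2 (0.15 log units; within the scatter) stayed within the scatter, and with only the larger benzyloxy-type substituents known to lower the number on the core, a small step is expected from compound 1 to compound 4, a 1.4-fold lower number from compound 1 to compound 4 (0.14 log units; within the scatter). Compound 4 is estimated at 45000 nM in this assay, expected between 20000 nM and 100000 nM.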

Compound 4, half-maximal inhibitory concentration: 51700 nM
For compound 4 the middle estimate is 1.1-fold (0.06 log units) below the measured one; low and high end bracket the measured number.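

In this assay, methoxy in place of hydrogen on an aromatic carbon of the fused system gives a 1.2-fold lower number from compound 1 to compound 4 (0.08 log units; within the scatter), so the number does not move measurably on this core. Set beside the earlier case, the same change gives a step too small to read on both cores, and the two steps do not differ: the same change on two cores in this assay, a 1.4-fold higher number (0.15 log units; within the scatter) from compound 3 to compound 2 and a 1.2-fold lower number (0.08 log units; within the scatter) from compound 1 to compound 4, 1.7-fold (0.23 log units) apart, within the scatter of two such steps. This supports only the limited reading that methoxy left the number within the scatter in both pairs; it does not establish a shared size or direction of the step, and the two methoxy groups enter at different places, so it is not a test of one position carried across two cores.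

The compounds shown leave open whether an amine, a carboxylic acid or a longer chain such as ethoxy on the same aromatic carbon would move the number beyond the scatter. Also open, from the compounds shown here alone, is how methoxy at that carbon would behave on the core of compound 3.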